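Moving the pyrazole attachment point on an imidazoline agonist

A few compounds are considered here, and "the series" means these few. Any claim that something is new, unique, unknown or untested is made for them only; others in the source may bear on it.

Compound 2 `Cn1ccc(-c2ccccc2NCC2=NCCN2)n1` gives 15.9 nM in an in vitro functional assay on cells (Fibroblast) for agonist activity at Alpha-1D adrenergic receptor (Homo sapiens) (on this read-out lower numbers stand for an effect already at smaller amounts and higher numbers for an effect only at larger amounts of compound), the lowest of the two numbers at hand; compound 1 `Cn1ncnc1-c1ccccc1NCC1=NCCN1` gives 63.1 nM. Compound 3 `Cn1cc(-c2ccccc2NCC2=NCCN2)cn1` differs from compound 2 by 1-methyl-1H-pyrazol-4-yl in place of 1-methyl-1H-pyrazol-3-yl on an aromatic carbon. For the measured compounds named here, the only measured step, a 4.0-fold lower number from compound 1 to compound 2 (0.60 log units; beyond the scatter), shows that exchanging one five-membered heteroaryl for another shifts the read-out modestly, so a step of similar size in either direction is plausible here. Compound 3 is expected at 30 nM (range 8 nM to 110 nM), meaning an expected step of a 1.9-fold higher number from compound 2 to compound 3 (0.28 log units; within the scatter).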

Compound 3, half-maximal effective concentration: < 100000 nM
Compound 3: no number, only a limit; the forecaster's own chance of this, stated with the estimate: 5%; the middle value is on the limit's open side.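

In this assay compound 3 gives < 100000 nM, a limit and not a number, so its steps from compound 1 and compound 2 cannot be read. The compounds shown leave open how far 1-methyl-1H-pyrazol-4-yl in place of 1-methyl-1H-pyrazol-3-yl moves the read-out.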